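Swapping Iodo for Ethyl: Expected Binding of Compound 3

The source may hold more compounds than are shown below. What is called first, only, known or untested is meant among the compounds shown, and "the series" means these compounds.

Compound 1 `CCc1nc(-c2ccc(Cl)cc2Cl)c(CC)nc1SC(C)CC`; in an assay on IMR-32 cells for displacement of a labelled ligand from corticotropin-releasing factor receptor 1 (Homo sapiens), read by scintillation counting, with a stated time of 2 h (on this read-out lower numbers stand for stronger inhibition and higher numbers for weaker inhibition), compound 1 gives 401 nM.
Compound 2 `CCc1nc(NC(CC)CC)c(I)nc1-c1ccc(Cl)cc1Cl`; in this assay compound 2 gives 12 nM.

Of the two measured compounds, compound 2 has the lower number, and compound 1 stands far above it, a gap beyond the usual scatter. Compound 3 `CCc1nc(-c2ccc(Cl)cc2Cl)c(CC)nc1NC(CC)CC` differs from compound 2 only by ethyl in place of iodo on an aromatic carbon. Within the data shown here, no measured pair shows this single change on its own, so the direction is uncertain; a moderate weakening, somewhat beyond the scatter, seems the more likely outcome. For compound 3 in this assay the expected value is 40 nM, with a range from 10 nM to 160 nM. That estimate amounts to an expected step of a 3.3-fold higher number from compound 2 to compound 3 (0.52 log units; beyond the scatter).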

Compound 3, inhibition constant: 4.1 nM
Compound 3: middle estimate off by 9.8-fold (0.99 log units), on the high side; measured number outside the range, below it.
By their numbers in this assay, from the lowest: compound 3; then compound 2; then compound 1.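

In this assay, ethyl in place of iodo gives a 2.9-fold lower number from compound 2 to compound 3 (0.47 log units; beyond the scatter) and so this aromatic carbon, ortho to the (pentan-3-yl)amino group, serves better with ethyl than with iodo. With ethyl in this position in both compounds, (pentan-3-yl)amino in place of (sec-butyl)sulfanyl gives a 98-fold lower number from compound 1 to compound 3 (1.99 log units; beyond the scatter) as a much larger step, showing that the change at that other carbon counts for more here. Nothing at hand explains either step. From the compounds shown here alone, whether methyl, a longer chain such as propyl, or an amine on this carbon would do better remains open.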